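A few compounds are considered here, and "the series" means these few. Any claim that something is new, unique, unknown or untested is made for them only; others in the source may bear on it.

Measured so far in an assay on HEK293 cells for displacement of a labelled ligand from growth hormone secretagogue receptor type 1 (Homo sapiens), with a stated time of 60 min; on this read-out lower numbers stand for stronger inhibition and higher numbers for weaker inhibition:
compound 1 `CS(=O)(=O)c1ccc2nc(NC(=O)NC(=O)c3ccccc3Cl)sc2c1` — 120 nM
compound 2 `CC(C)NCCS(=O)(=O)c1ccc2nc(NC(=O)NC(=O)c3ccccc3Cl)sc2c1` — 27 nM

Among the compounds with values here, compound 2 stands lowest of the two numbers in this assay; its only neighbour is compound 1, and the single measured step, a 4.4-fold lower number from compound 1 to compound 2 (0.65 log units; beyond the scatter), is the one that separates them. Compound 3 `CN(C)CCCS(=O)(=O)c1ccc2nc(NC(=O)NC(=O)c3ccccc3Cl)sc2c1` is not yet measured. The change from compound 2 is (dimethylamino)methyl in place of isopropylamino on a saturated chain carbon, two bonds along the chain from a sulfonyl sulfur; the two share the same atoms, joined differently. Within the data shown here, no measured pair carries a rearrangement of this kind. The step of a 4.4-fold lower number from compound 1 to compound 2 (0.65 log units; beyond the scatter) bears on it only in so far as it shows that a chain ending in an amine lowered the number when it was introduced, and compound 3 keeps such a chain. Nothing measured shows what moving the amine along the chain does. A step within the scatter is therefore expected, a 1.1-fold higher number from compound 2 to compound 3 (0.05 log units; within the scatter). Compound 3 is estimated at 30 nM, with a range from 10 nM to 90 nM.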

Compound 3, half-maximal inhibitory concentration in the growth hormone secretagogue receptor type 1 assay: 8.7 nM
The estimate for compound 3 lay 3.4-fold (0.54 log units) above the measured number, outside the stated range (below it).
By their numbers in the growth hormone secretagogue receptor type 1 assay, from the lowest: compound 3; then compound 2; then compound 1.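

In the growth hormone secretagogue receptor type 1 assay, the arrangement of the amine on the sulfonyl chain matters as well as its presence: with the same atoms, (dimethylamino)methyl in place of isopropylamino gives a 3.1-fold lower number from compound 2 to compound 3 (0.49 log units; beyond the scatter). Measured against the core of compound 1, 2-(dimethylamino)ethyl in place of hydrogen on the saturated chain carbon bound to the sulfonyl sulfur gives a 14-fold lower number from compound 1 to compound 3 (1.14 log units; beyond the scatter). This lower number does not come with a higher one in a physicochemical assay for lipophilicity; on this read-out lower numbers stand for lower lipophilicity and higher numbers for higher lipophilicity: the measured distribution coefficient of compound 2, 2.3, and of compound 3, 1.7, a number 0.60 log units lower (beyond the scatter) In the physicochemical assay compound 2 gives 2.3 and compound 3 gives 1.7.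

The change alters the chain length and the substitution on the amine together, and the compounds shown do not separate the two. As far as these compounds go, how a 3-(isopropylamino)propyl chain, a longer chain ending in dimethylamino, or a carboxylic acid in place of the amine would read in the growth hormone secretagogue receptor type 1 assay remains open.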